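The source may hold more compounds than are shown below. What is called first, only, known or untested is meant among the compounds shown, and "the series" means these compounds.

Measured so far:
- compound 1, `N[C@@H](CCCCCC(=O)c1cocn1)c1ncc(-c2ccccc2F)[nH]1`: > 45000 nM
- compound 2, `COc1nc2ccccc2cc1-c1cnc([C@@H](N)CCCCCC(=O)c2cc[nH]n2)[nH]1`: "not determined" (no result reported)

In an ADME assay on isolated protein for inhibition of protein deacetylase HDAC6 (Homo sapiens), read by fluorescence, with stated times of 3 h and 60 min (on this read-out lower numbers stand for stronger inhibition and higher numbers for weaker inhibition), compound 1 gives > 45000 nM, and this is a limit of the assay rather than a number. For compound 2 in this assay the result is recorded as "not determined" (no result reported), so compound 2 stands nowhere on the numbers shown: of the two values, one sits at the limit of > 45000 nM in this assay, at which 1 of the 2 values shown sits, and the other is missing. Going by the values given here, no step between measured compounds exists here.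

Compound 3, `COc1nc2ccccc2cc1-c1cnc([C@@H](N)CCCCCC(=O)c2cnoc2C)[nH]1`, is the next compound to be measured in this assay. It differs from compound 2 in one place, (5-methyl-1,2-oxazol-4-yl in place of 1H-pyrazol-3-yl on a carbonyl carbon). Among the compounds with values here, with no measured step and no number for compound 2, the size and direction of this change cannot be read from the data; the one value that exists, for compound 1, is a limit, and it sets the only landmark.

Compound 3 is expected to give 15000 nM in this assay, within a wide range from 1500 nM to 45000 nM, and a limit rather than a number would not be surprising.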

Compound 3, half-maximal inhibitory concentration: > 45000 nM
Compound 3: no number, only a limit; the forecaster's own chance of this, stated with the estimate: 45%; middle value at least 3.0-fold (0.47 log units) away from the limit.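

No step can be read between compound 2 and compound 3: compound 2 has no reported result, and compound 3 carries only a limit of the assay, not a number. The compounds shown leave open whether replacing 1H-pyrazol-3-yl with 5-methyl-1,2-oxazol-4-yl on the carbonyl carbon changes inhibition at all.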